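Swapping a brominated ring on a well-tolerated amide

The source may hold more compounds than are shown below. What is called first, only, known or untested is meant among the compounds shown, and "the series" means these compounds.

compound 1 `O=C(Nc1cccc(Cl)c1)c1cccc(Br)c1`: 51000 nM
compound 2 `COc1c(Br)cc(Br)cc1C(=O)Nc1ccc(Sc2nc3ccccc3s2)c(Cl)c1`: > 100000 nM
compound 3 `COc1c(Br)cc(Br)cc1C(=O)Nc1cccc(Cl)c1`: > 100000 nM

Among the compounds with values here, in an ADME assay on HEK293 cells (Homo sapiens) for cytotoxicity, read by reporter gene assay and resazurin assay, with a stated time of 48 h (a higher number here means that more compound is tolerated, a lower number that less compound is tolerated), compound 1 gives 51000 nM, the only true number so far. Compound 2 gives no number, only a limit: > 100000 nM. That is the limit of > 100000 nM in this assay, at which 2 of the 3 values shown sit. Compound 3 also gives only a limit, > 100000 nM.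

The next compound, compound 4 `COc1ccccc1C(=O)Nc1ccc(Sc2nc3ccccc3s2)c(Cl)c1`, keeps all of compound 2 except the group on the carbonyl carbon: a group of 8 heavy atoms (7 carbon, 1 oxygen; one six-membered aromatic ring of carbon only) in place of a group of 10 heavy atoms (7 carbon, 1 oxygen, 2 bromine; one six-membered aromatic ring of carbon only), on a carbonyl carbon. One measured step can be consulted, a step that the two limits leave unreadable from compound 2 to compound 3. It alters a different place, and its size cannot be read, so it offers no size to carry over to this change. With no readable step to go on, no change beyond the usual scatter is expected in this assay, and a limit may well be all that is reported again. A lower reading stays possible, since compound 1 gives 51000 nM. The expected step is an at least 1.1-fold lower number from compound 2 to compound 4 (0.04 log units; that floor lies within the scatter). For compound 4 the estimated value is 90000 nM, with an expected range from 35000 nM to 150000 nM.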

Compound 4, half-maximal cytotoxic concentration: > 100000 nM
Compound 4 ended at the assay's limit; the forecaster's own chance of this, stated with the estimate: 65%; middle value at least 1.1-fold (0.04 log units) from the limit.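

In this assay compound 4 gives only a limit, > 100000 nM. Compound 2 gives a limit too, so no step from compound 2 to compound 4 can be read: the limit of > 100000 nM in this assay, at which 3 of the 4 values shown sit.

The compounds shown leave open whether 2-methoxyphenyl on the carbonyl carbon, in place of the group with two bromines, changes how much compound is tolerated.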